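The source may report more compounds than this note shows. Statements on the series, on what has been measured and on what is new or still open speak of the compounds shown alone.

Measured compounds:
- compound 1, `O=C(O)CC/C=C\CC1COC(c2ccc(Cl)cc2Cl)OC1c1cccnc1`: 2500 nM
- compound 2, `Cc1ccc(OC(C)(C)C2OCC(C/C=C\CCC(=O)O)C(c3cccnc3)O2)cc1`: 25000 nM

In an assay for inhibition of prostacyclin synthase (Homo sapiens), using microsomes (on this read-out lower numbers stand for stronger inhibition and higher numbers for weaker inhibition), compound 1 gives 2500 nM, and compound 2 gives 25000 nM. Of these two numbers compound 2 stands at the higher one, a gap from compound 1 that lies beyond the usual scatter, so compound 2 is the weaker inhibitor of the pair.

Compound 3, `CC(C)(Cc1ccc(F)cc1)C1OCC(C/C=C\CCC(=O)O)C(c2cccnc2)O1`, has not yet been measured in this assay. It differs from compound 2 in one place: 4-fluorobenzyl in place of 4-methylphenoxy on a saturated chain carbon bound to two saturated chain carbons and a saturated ring carbon. The rest of the molecule, including the acid-bearing chain and the pyridine-bearing ring, is unchanged.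

Among the compounds with values here, since no pair of measured compounds differs in only one place, there is no directly comparable step to lean on. The step from compound 2 to compound 3 is expected to be small and toward lower numbers, roughly a 2.5-fold lower number from compound 2 to compound 3 (0.40 log units; beyond the scatter), close to the edge of the scatter. Compound 3 is therefore estimated at 10000 nM, with a range from 2000 nM to 50000 nM.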

Compound 3, half-maximal inhibitory concentration: 2000 nM
For compound 3 the middle estimate is 5.0-fold (0.70 log units) above the measured one; the measured number falls inside the stated range.
By their numbers in this assay, from the lowest: compounds 3 and 1 (each within the scatter of the next); then compound 2.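

In this assay, the saturated chain carbon bound to two saturated chain carbons and a saturated ring carbon proves sensitive to what it carries: 4-fluorobenzyl in place of 4-methylphenoxy gives a 13-fold lower number from compound 2 to compound 3 (1.10 log units; beyond the scatter). This large step comes with no change in heavy-atom count, and each group holds one six-membered aromatic ring of carbon only, so a swap that keeps both of those counts can still move the number strongly here. Nothing measured here explains the step.

The swap alters two things at once, as the oxygen of 4-methylphenoxy and its methyl both leave while a carbon link and a fluorine enter, and the compounds shown do not tell these apart. Going by these compounds, it remains open whether 4-fluorophenoxy or 4-methylbenzyl at this place would give a number nearer to compound 2 or to compound 3.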